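A New Side Group on a Chloro Compound

The compounds below may be only part of what the source reports. "The series", "measured", "known", "first", "only" and "open" are said of these compounds alone.

In a functional assay on V79 cells (Cricetulus griseus) for cytotoxicity, read by colony formation (a higher number here means a weaker inhibitor, a lower number a stronger inhibitor), compound 1 `O=C(O)c1cn(C2CC2)c2c(Cl)c(N3CCCC3)c(F)cc2c1=O` gives 150 ug/mL, level with compound 2 `COc1c(N2CCCC2)c(F)cc2c(=O)c(C(=O)O)cn(C3CC3)c12` at 150 ug/mL. Compound 3 `O=C(O)c1cn(C2CC2)c2c(C(F)(F)F)c(N3CCCC3)c(F)cc2c1=O` gives 280 ug/mL. Compound 4 `CC1(CN)CCN(c2c(F)cc3c(=O)c(C(=O)O)cn(C4CC4)c3c2Cl)C1` keeps the chloro group and changes another place: 3-(aminomethyl)-3-methylpyrrolidin-1-yl in place of pyrrolidin-1-yl on an aromatic carbon. The measured steps concern only the swap of the chloro group: no change at the digits printed from compound 1 to compound 2 (within the scatter), and a 1.9-fold higher number from compound 1 to compound 3 (0.27 log units; within the scatter). Neither touches the pyrrolidine, so they give no direct size for this change. A step toward a lower number in this assay is still expected, as a judgement with wide uncertainty rather than a measured trend. The estimated step is a 3.0-fold lower number from compound 1 to compound 4 (0.48 log units; beyond the scatter). For compound 4 the estimated value is 50 ug/mL, with an expected range from 12 ug/mL to 200 ug/mL.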

Compound 4, half-maximal inhibitory concentration: 8 ug/mL
Compound 4: the middle estimate sits 6.3-fold (0.80 log units) above what was measured, outside the stated range (below it).
By their numbers in this assay, from the lowest: compound 4; then compounds 1, 2 and 3 (each within the scatter of the next).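

In this assay, the aromatic carbon ortho to a chloro group and ortho to a fluoro group proves sensitive: 3-(aminomethyl)-3-methylpyrrolidin-1-yl in place of pyrrolidin-1-yl gives a 19-fold lower number from compound 1 to compound 4 (1.27 log units; beyond the scatter) in this single swap. Among the compounds shown here, the earlier swaps of the chloro group all stayed within the scatter, so this is the first step here that lies beyond it. Nothing available explains the size of this step.

As far as these compounds go, the new group carries both a methyl and an aminomethyl, so the share of each remains unknown. From the compounds shown here alone, whether a hydroxymethyl group in place of the aminomethyl would give a similar step, and whether the step holds with methoxy or trifluoromethyl in place of the chloro group, stays open.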